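A few compounds are considered here, and "the series" means these few. Any claim that something is new, unique, unknown or untested is made for them only; others in the source may bear on it.

Measured so far in a functional assay on B16-F0 cells (Mus musculus) for inhibition, read by CCK-8 assay, with a stated time of 48 h; a higher number here means a weaker inhibitor, a lower number a stronger inhibitor:

compound 1 `COc1cc(-c2ccnc3cc(-c4ccc5ccn(C)c5c4)nn23)cc(OC)c1OC`: 657 nM
compound 2 `COc1cc(-c2ccnc3cc(-c4cn(C(=O)OC(C)(C)C)c5ccccc45)nn23)cc(OC)c1OC`: 3070 nM
compound 3 `COc1cc(-c2ccnc3cc(-c4cccc5c4ccn5CO)nn23)cc(OC)c1OC`: 1090 nM

Compound 1 has the lowest number of the three. Compound 3 sits closest to it, and the gap between compound 1 and compound 3 lies within the scatter of repeated runs, so the two cannot be told apart on these data. Compound 2 sits furthest from compound 1, with a gap beyond the scatter, so compound 2 is a weaker inhibitor than compound 1 in this assay. All three share the same core and the same trimethoxyphenyl; they differ only in the group on the other side of the core.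

Compound 4 `C=Cc1ccc(-c2cc3nccc(-c4cc(OC)c(OC)c(OC)c4)n3n2)cc1` has not yet been measured. Relative to compound 1 the change is:
4-vinylphenyl in place of 1-methyl-1H-indol-6-yl on an aromatic carbon

For the measured compounds named here, no step between measured compounds matches this change, and no measured compound carries a group of this kind, so the expectation rests on the spread of the three values alone. The step from compound 1 to compound 4 is expected to be small and toward a higher number, a 1.8-fold higher number from compound 1 to compound 4 (0.26 log units; within the scatter), and it may not rise beyond the scatter. For compound 4 in this assay the estimate is 1200 nM, with a range from 400 nM to 4000 nM.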

Compound 4, half-maximal inhibitory concentration: 788 nM
Compound 4: the middle estimate sits 1.5-fold (0.18 log units) above what was measured; low and high end bracket the measured number.
By their numbers in this assay, from the lowest: compounds 1, 4 and 3 (each within the scatter of the next); then compound 2.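

In this assay the replacement of 1-methyl-1H-indol-6-yl by 4-vinylphenyl gives a 1.2-fold higher number from compound 1 to compound 4 (0.08 log units; within the scatter), so the two groups cannot be told apart at this position, on an aromatic carbon of the five-membered aromatic ring of the shared core. This pair shows that the position can take a group without the five-membered aromatic ring and without the ring nitrogen of the indole, since a single six-membered aromatic ring of carbon only, carrying a double bond outside the ring, gives a number that cannot be separated from that of compound 1. No measured data bear on why the two groups give matching numbers.

On these data alone, it remains open whether the double bond of the vinyl group matters at all, which an ethyl group or a longer chain in its place on the same phenyl would test. Also open, as far as these compounds go, is how this position responds to a group that brings in a hydrogen-bond donor or a charge, such as an amine or a carboxylic acid on that phenyl.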